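Rat Oral Exposure: From Compound 1 to Compound 3

The source may hold more compounds than are shown below. What is called first, only, known or untested is meant among the compounds shown, and "the series" means these compounds.

The study compares three close analogues on a shared core. Compound 1, `Cc1cn2c(-c3cn[nH]c3)cnc2c(Nc2cc(Cn3cccc(C)c3=O)ns2)n1`, was examined in an ADME assay on the whole organism for pharmacokinetics, with Rattus norvegicus as the target, with a stated time of 6 h, at a dose of 10 mg/kg by the oral route (on this read-out higher numbers stand for higher exposure at the dose given and lower numbers for lower exposure), but no single number is reported for it: in this assay compound 1 gives "not determined" (no result reported), so compound 1 cannot be placed on this scale. Compound 2, `Cc1cn2c(-c3cn[nH]c3)cnc2c(Nc2cc(Cc3ncccc3F)ns2)n1`, was measured: in this assay compound 2 gives 569 ng.h/mL. Compound 3, `Cc1cn2c(-c3cn[nH]c3)cnc2c(Nc2cc(Cc3ccc(F)cn3)ns2)n1`, has not yet been measured in this assay.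

Compound 3 differs from compound 1 at one place: a group of 7 heavy atoms (5 carbon, 1 nitrogen, 1 fluorine; one six-membered aromatic ring with 1 hetero atom) in place of a group of 8 heavy atoms (6 carbon, 1 nitrogen, 1 oxygen; one six-membered aromatic ring with 1 hetero atom), on a saturated chain carbon bound to an aromatic carbon. Compound 1 has no number in this assay. For the measured compounds named here, the direction and size of the step from compound 1 to compound 3 cannot be set against a starting point, and no step between measured compounds is available to guide it. Going by the values given here, the only anchor is compound 2, which gives 569 ng.h/mL in this assay and carries the shared core together with a group of the same kind, a six-membered aromatic ring with one hetero atom bearing a fluorine.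

On that basis compound 3 is expected to give about 500 ng.h/mL in this assay, with a range from 150 ng.h/mL to 1600 ng.h/mL, which is broad because compound 2 gives 569 ng.h/mL and nothing else constrains the estimate.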

Compound 3, area under the concentration-time curve: 2240 ng.h/mL
Compound 3: middle estimate off by 4.5-fold (0.65 log units), on the low side, outside the stated range (above it).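

In this assay the result shows that the group on a saturated chain carbon bound to an aromatic carbon matters for more than its general kind: with 5-fluoropyridin-2-yl in place of 3-fluoropyridin-2-yl, the data give a 3.9-fold higher number from compound 2 to compound 3 (0.60 log units; beyond the scatter) and this step lies beyond the usual scatter. For the compounds shown here, the earlier compounds could not show this, as only one number was available and a single value says nothing about how a change at this place moves the read-out. The step from compound 1 to compound 3 cannot be read, as compound 1 has no number, so the group of compound 1 remains unplaced against either fluoropyridine, and nothing shown here gives a measured reason for the difference between compound 2 and compound 3.

The compounds shown leave open whether the fluorine itself contributes to the exposure of compound 3 or whether a plain pyridin-2-yl group would do as well. They also leave open how a 5-chloropyridin-2-yl group, a 5-methoxypyridin-2-yl group or a phenyl ring at this same place would compare with the 5-fluoropyridin-2-yl group.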